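Nitrile chain length on the shared core

The source may report more compounds than this note shows. Statements on the series, on what has been measured and on what is new or still open speak of the compounds shown alone.

compound 1 `Cc1nc2c(Br)c(Br)c(Br)c(Br)c2n1CCCC#N`: 1%
compound 2 `N#CCCCCn1cnc2c(Br)c(Br)c(Br)c(Br)c21`: 1%

In a functional assay on CCRF-CEM cells (Homo sapiens) for cytotoxicity, read by MTT assay, with a stated time of 24 h, tested at 50 uM (on this read-out higher numbers stand for a weaker effect at the one concentration tested and lower numbers for a stronger effect), compound 1 gives 1%. In this assay compound 2 gives 1%, level with compound 1 at the digits shown, the gap lying within the usual scatter of this read-out. Compound 3 `N#CCCCn1cnc2c(Br)c(Br)c(Br)c(Br)c21` has not been measured. It differs from compound 2 in a single place: cyano in place of cyanomethyl on a saturated chain carbon, three bonds along the chain from an aromatic nitrogen. Within the data shown here, no step between measured compounds is available to guide the expectation; the two measured values show only that both chain lengths give a very weak effect at the one concentration tested. The change in chain length from compound 2 to compound 3 is expected to move the read-out by no more than the scatter. Compound 3 is therefore estimated to give 3%, with a range from 0% to 15%. The expected step is a number 2 percentage points higher from compound 2 to compound 3 (within the scatter), none beyond the scatter.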

Compound 3, a percentage reported as activity, at one concentration (the size of the read-out at that concentration, not a potency): 2%
Compound 3: the middle estimate sits 1 percentage points above what was measured; measured number inside the range.
By their numbers in this assay, from the lowest: compounds 1, 2 and 3 (each within the scatter of the next).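

In this assay, cutting the chain from 4-cyanobutyl to 3-cyanopropyl, with cyano in place of cyanomethyl on a saturated chain carbon, three bonds along the chain from an aromatic nitrogen, gives a number 1 percentage points higher from compound 2 to compound 3 (within the scatter), the first single-place step read at this position. Compound 3 also provides a single-place comparison on the core, where hydrogen in place of methyl on an aromatic carbon gives a number 1 percentage points higher from compound 1 to compound 3 (within the scatter). No measurement shown here accounts for either step.

As far as these compounds go, whether a longer chain than 4-cyanobutyl, or an amine or a carboxylic acid in place of the nitrile, would stay level on this read-out remains open. Also open, from the compounds shown here alone, is how ethyl or phenyl would read on the aromatic carbon that carries methyl in compound 1.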